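Aryl cyanoaziridine ureas: ester for fluoro swap

The compounds below may be only part of what the source reports. "The series", "measured", "known", "first", "only" and "open" are said of these compounds alone.

The series shares a cyanoaziridine urea. Compound 1 `CCOC(=O)CNC(=O)N1CC1C#N` carries an ethyl glycinate on the urea and in a functional assay on A-375 cells (Homo sapiens) for inhibition (on this read-out higher numbers stand for weaker inhibition and lower numbers for stronger inhibition), compound 1 gives 51000 nM. Compound 2 `N#CC1CN1C(=O)Nc1ccc(Cl)c(Cl)c1` gives 5900 nM in this assay, and compound 3 `N#CC1CN1C(=O)Nc1ccc(F)cc1` gives 3400 nM. Compound 3 sits at the low end of the three numbers, with compound 2 within the scatter of it and compound 1 far beyond. Compound 4 `CCOC(=O)c1ccc(NC(=O)N2CC2C#N)cc1` differs from compound 3 by ethoxycarbonyl in place of fluoro on an aromatic carbon. Among the compounds with values here, no measured pair shows this change. Since both aryl ureas lie close together, the step from compound 3 to compound 4 is expected to be small, likely none beyond the scatter, a 1.5-fold higher number from compound 3 to compound 4 (0.17 log units; within the scatter). Compound 4 is estimated at 5000 nM, between 1500 nM and 17000 nM.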

Compound 4, half-maximal inhibitory concentration: 5800 nM
Compound 4: middle estimate off by 1.2-fold (0.06 log units), on the low side; the range from low to high includes it.
By their numbers in this assay, from the lowest: compounds 3, 4 and 2 (each within the scatter of the next); then compound 1.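

In this assay, within the data shown here, ethoxycarbonyl in place of fluoro on this aromatic carbon gives a 1.7-fold higher number from compound 3 to compound 4 (0.23 log units; within the scatter) and provides the first comparison that differs in one place. The 5 heavy atoms of ethoxycarbonyl, with its 2 hydrogen-bond acceptors, replace a single fluorine without a change beyond the scatter. No measured evidence bears on this result.

Going by these compounds, whether a carboxylic acid, an amine or a longer ester chain on this carbon would also stay within the scatter of compound 3 remains open. Also open, on these data alone, is whether ethoxycarbonyl behaves the same elsewhere on the aromatic ring.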